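Aryl swap on the hydrazone carbon: outlook for compound 3

The source may report more compounds than this note shows. Statements on the series, on what has been measured and on what is new or still open speak of the compounds shown alone.

Measured compounds:
- compound 1, `NS(=O)(=O)c1ccc(Nc2nc(N/N=C/c3ccc(C(F)(F)F)cc3)nc(Nc3ccccc3)n2)cc1`, in a functional assay on SF-539 cells (Homo sapiens) for inhibition, read by sulforhodamine B assay, with a stated time of 48 h; on this read-out lower numbers stand for stronger inhibition of growth and higher numbers for weaker inhibition of growth: 1860 nM
- compound 2, `Cc1nn(-c2ccccc2)cc1/C=N/Nc1nc(Nc2ccccc2)nc(Nc2ccc(S(N)(=O)=O)cc2)n1`: 1710 nM

The two numbers stand within the scatter of each other, so compound 2 is not separated from compound 1 by this assay; the step of a 1.1-fold lower number from compound 1 to compound 2 (0.04 log units; within the scatter) is the only one available. Compound 3, `NS(=O)(=O)c1ccc(Nc2nc(N/N=C/c3ccccn3)nc(Nc3ccccc3)n2)cc1`, differs from compound 2 by pyridin-2-yl in place of 3-methyl-1-phenyl-1H-pyrazol-4-yl on a carbon with a double bond to nitrogen. Within the data shown here, the one step that bears on this position, the swap of the aryl group from compound 1 to compound 2, was a 1.1-fold lower number from compound 1 to compound 2 (0.04 log units; within the scatter), and it did not move the number beyond the scatter. Among the measured compounds shown here, only one such step is known, so the expectation rests on a thin base. For compound 3 a step of a 1.0-fold lower number from compound 2 to compound 3 (0.00 log units; within the scatter) is expected, that is, no change beyond the scatter. Compound 3 is therefore estimated at 1700 nM, with a range from 800 nM to 3600 nM.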

Compound 3, concentration for 50% growth inhibition: 680 nM
Beside the measured number, compound 3's estimate is 2.5-fold (0.40 log units) above it; the measured number lies below the stated range.
By their numbers in this assay, from the lowest: compound 3; then compounds 2 and 1 (each within the scatter of the next).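

The group on the carbon with a double bond to nitrogen can move the number in this assay beyond the scatter: pyridin-2-yl gives a 2.5-fold lower number from compound 2 to compound 3 (0.40 log units; beyond the scatter) and a 2.7-fold lower number from compound 1 to compound 3 (0.44 log units; beyond the scatter) in working terms, whereas the earlier exchange of 4-(trifluoromethyl)phenyl for 3-methyl-1-phenyl-1H-pyrazol-4-yl gave no separation. The position is therefore not indifferent to the aryl group, and the modest gain appears against both other groups, not just one. No measurement shown accounts for this gain.

The three compounds leave open whether the gain follows the ring nitrogen of pyridin-2-yl or the smaller size of the group. Also open, going by these compounds, is how an unsubstituted phenyl or an open-chain amine on this carbon would compare with pyridin-2-yl.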